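Aryl to arylmethyl swap on the ring amine nitrogen

The compounds below may be only part of what the source reports. "The series", "measured", "known", "first", "only" and "open" are said of these compounds alone.

Compound 1 `Nc1ccccc1NC(=O)c1ccc(CSC(=S)N2CCN(c3cccnc3)CC2)cc1` and compound 2 `Nc1ccccc1NC(=O)c1ccc(CSC(=S)N2CCN(c3ncccn3)CC2)cc1` share one core and differ only in the group on an amine nitrogen in a ring. Among the measured compounds shown here, in a functional assay on A-375 cells (Homo sapiens) for antiproliferative activity, read by CCK-8 assay, with a stated time of 72 h, tested at 8 uM (a lower number here means a weaker effect, a higher number a stronger effect of the compound at the concentration tested), compound 1 gives 88.8%, while compound 2 gives 67.9%, the lowest of the two numbers so far. For the measured compounds named here, the one step available, a number 20.9 percentage points lower from compound 1 to compound 2 (beyond the scatter), is thus a modest loss beyond the scatter.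

Compound 3 `Nc1ccccc1NC(=O)c1ccc(CSC(=S)N2CCN(Cc3cccnc3)CC2)cc1` is the next member; its change from compound 2 is (pyridin-3-yl)methyl in place of pyrimidin-2-yl on an amine nitrogen in a ring. The pyrimidin-2-yl that cost the modest loss from compound 1 to compound 2 leaves, and a pyridin-3-yl ring returns, now carried on a methylene. Going by the values given here, the only step that bears on this is the one from compound 1 to compound 2, which argues that removing pyrimidin-2-yl should recover part of that loss; the added methylene has no counterpart among the measured pairs, so the size of the recovery is uncertain.

For compound 3 in this assay a rise is expected, a number 12.1 percentage points higher from compound 2 to compound 3 (beyond the scatter), giving an estimated 80% with a range from 62% to 95%.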

Compound 3, a percentage reported as inhibition, at one concentration (the size of the read-out at that concentration, not a potency): 89.2%
Beside the measured number, compound 3's estimate is 9.2 percentage points below it; measured number inside the range.
By their numbers in this assay, from the lowest: compound 2; then compounds 1 and 3 (each within the scatter of the next).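

In this assay a methylene can be carried on the amine nitrogen in a ring with no readable effect, as the comparison shows with a number 0.4 percentage points higher from compound 1 to compound 3 (within the scatter) between two compounds that both hold a pyridin-3-yl ring. The reverse of the earlier loss now appears from a second side, with a number 21.3 percentage points higher from compound 2 to compound 3 (beyond the scatter) in the swap of pyrimidin-2-yl for (pyridin-3-yl)methyl, so that compound 2 is the only one of the three set apart by a step beyond the scatter, and both steps that leave it end in a pyridin-3-yl ring, with or without the methylene. Nothing measured on these compounds gives a reason for the gap between the two ring types.

Still open, from the compounds shown here alone, is whether the lower number of compound 2 goes with the pyrimidin-2-yl ring itself or with its being carried directly on the nitrogen, which a (pyrimidin-2-yl)methyl group would separate, while a longer chain such as (pyridin-3-yl)ethyl would test how far the ring can move from that nitrogen. A read-out at one concentration also shows only the size of the effect of compound 1 and compound 3 at that concentration, and whether the two would still match at other concentrations remains unresolved.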